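Diaryl substitution on the shared core: compound 4 expected

The compounds below may be only part of what the source reports. "The series", "measured", "known", "first", "only" and "open" are said of these compounds alone.

Measured so far:
compound 1 `O=C(Nc1cccc(CNc2nccnc2Cl)c1)Nc1ccc(F)c(Cl)c1`: 5020 nM
compound 2 `O=C(Nc1cccc(CNc2nccnc2Cl)c1)NC1CCCC1`: 23400 nM
compound 3 `CS(=O)(=O)c1ccc(NC(=O)Nc2cccc(CNc3nccnc3Cl)c2)cc1`: 12300 nM

In a functional assay on MGC-803 cells (Homo sapiens) for antiproliferative activity, read by MTT assay, with a stated time of 48 h (a higher number here means a weaker inhibitor, a lower number a stronger inhibitor), compound 1 gives 5020 nM, the lowest of the three numbers. Compound 3 gives 12300 nM in this assay, and compound 2 gives 23400 nM, so compound 1 stands clear of both.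

Compound 4 `Cc1ccc(NC(=O)Nc2cccc(CNc3nccnc3Cl)c2)cc1` is not yet measured. It differs from compound 1 at one site: 4-methylphenyl in place of 3-chloro-4-fluorophenyl on an amide-type nitrogen.

Going by the values given here, one measured step bears directly on this change: a 4.7-fold higher number from compound 1 to compound 2 (0.67 log units; beyond the scatter), where the six-membered aromatic ring on the amide-type nitrogen was exchanged for a saturated ring. Compound 4 keeps a six-membered aromatic ring of carbon only at that position, so the larger part of that penalty should not apply. Among the compounds with values here, the comparison of compound 1 with compound 3 shows that a different substituent on the same ring also gives a higher number, though no single step is worked out for that pair.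

For compound 4 a modest rise is therefore expected, a 1.6-fold higher number from compound 1 to compound 4 (0.20 log units; within the scatter), with the estimate at 8000 nM and a range of 4000 nM to 20000 nM.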

Compound 4, half-maximal inhibitory concentration: 11900 nM
Estimate against measurement, compound 4: 1.5-fold (0.17 log units) below; the measured number falls inside the stated range.
By their numbers in this assay, from the lowest: compound 1; then compounds 4, 3 and 2 (each within the scatter of the next).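

In this assay, a six-membered aromatic ring of carbon only on the amide-type nitrogen does not by itself preserve the number of compound 1: with 4-methylphenyl at that place there is a 2.4-fold higher number from compound 1 to compound 4 (0.37 log units; beyond the scatter). The saturated ring and the aromatic ring are no longer separated once the halogens are gone, with a 2.0-fold lower number from compound 2 to compound 4 (0.29 log units; within the scatter), and methyl and methylsulfonyl on the aromatic carbon are not separated either, with a 1.0-fold lower number from compound 3 to compound 4 (0.01 log units; within the scatter); among these four compounds, the step to compound 2 and the step to compound 4 therefore point to 3-chloro-4-fluorophenyl as the group that stands apart, not to the aromatic ring alone. Nothing measured here accounts for that difference.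

Still open, from the compounds shown here alone, is whether the chlorine or the fluorine alone on the phenyl ring would hold the number of compound 1, or whether both are needed. Also open, going by these compounds, is how an amine or a carboxylic acid on that ring, or a longer chain on the amide-type nitrogen, would compare with these four compounds.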